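Swapping pyrrolidine for imidazole on the alkyne chain

This account rests on a few compounds, and the source may have more. Where it says the series, first, only, none or still open, it means among the compounds named here.

Measured so far in a functional assay on the whole organism for antagonist activity, with Mus musculus as the target; a higher number here means that more compound is needed for the effect, a lower number that less compound is needed:
Compound 1 `CN1CCN(CC#CCn2ccnc2)C1=O`: > 100 mg/kg (a limit, not a number)
Compound 2 `CC(C#CCN1CCCC1)N1CCN(C)C1=O`: 37 mg/kg

In this assay, within the data shown here, compound 2 gives 37 mg/kg, the only true number so far. Its one measured companion offers no second number to set it against.

Compound 3 `CC(C#CCn1ccnc1)N1CCN(C)C1=O` is still unmeasured and differs from compound 2 in one group: 1H-imidazol-1-yl in place of pyrrolidin-1-yl on a saturated chain carbon bound to a triple-bonded carbon. In words, 1H-imidazol-1-yl stands in place of pyrrolidin-1-yl on a saturated chain carbon bound to a triple-bonded carbon.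

Among the measured compounds shown here, no measured pair shows this swap on its own, so the size of the step is a judgement. For the measured compounds named here, compound 1 is the only measured compound carrying 1H-imidazol-1-yl, and its result of > 100 mg/kg is a limit. That points towards a larger dose being needed in this assay, and a result reported only as a limit would be no surprise. The estimated change is a 2.4-fold higher number from compound 2 to compound 3 (0.39 log units; beyond the scatter), a clear move towards a larger dose. For compound 3 the expected value is 90 mg/kg, with an estimated range from 30 mg/kg to 270 mg/kg.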

Compound 3, dose for half-maximal effect: > 100 mg/kg
Compound 3 gave a limit, no number; the forecaster's own chance of this, stated with the estimate: 55%; middle value at least 1.1-fold (0.04 log units) from the limit.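

Among these compounds, on a saturated chain carbon bound to a triple-bonded carbon, the swap of pyrrolidin-1-yl for 1H-imidazol-1-yl now has a direct reading in this assay, with only this one group changing: the result is an at least 2.7-fold higher number from compound 2 to compound 3 (0.43 log units; beyond the scatter). More compound is needed once 1H-imidazol-1-yl stands in this place, and the change lies beyond the usual scatter, although only its smallest possible size is known. The step that concerns the methyl on the chain, between compound 1 and compound 3, cannot be read, and the full size of the swap stays unknown because the results for both compounds carrying 1H-imidazol-1-yl are limits, not numbers: the limit of > 100 mg/kg in this assay, at which 2 of the 3 values shown sit.

The compounds shown leave open whether the result of compound 2 belongs to pyrrolidin-1-yl alone or would also hold for another amine in the same place, such as piperidin-1-yl or dimethylamino. They also leave open what hydrogen in place of the chain methyl would do in a compound that carries pyrrolidin-1-yl.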